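The source may hold more compounds than are shown below. What is called first, only, known or untested is meant among the compounds shown, and "the series" means these compounds.

Compound 1 `O=[N+]([O-])c1c(CS(=O)(=O)c2ccccc2)nc2c(-c3ccccc3)cc(Cl)cn12`: > 15600 nM (a limit)
Compound 2 `O=[N+]([O-])c1c(CS(=O)(=O)c2ccccc2)nc2c(-c3ccc(F)cc3)cc(Cl)cn12`: > 15600 nM (a limit)

In an ADME assay on HepG2 cells (Homo sapiens) for cytotoxicity, read by MTT assay, with a stated time of 72 h (on this read-out lower numbers stand for higher toxicity in this test and higher numbers for lower toxicity in this test), compound 2 reads > 15600 nM, which is a limit of the assay and not a number. Within the data shown here, the same is true of compound 1, so the whole series so far is summed up by the limit of > 15600 nM in this assay, at which 2 of the 2 values shown sit. Among the measured compounds shown here, the one measured change is a step that the two limits leave unreadable from compound 1 to compound 2, and it offers no size to carry forward.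

Compound 3 `O=[N+]([O-])c1c(CS(=O)(=O)c2ccccc2)nc2c(-c3ccccc3F)cc(Cl)cn12` keeps the same atoms but moves the fluorine on the phenyl ring: 2-fluorophenyl in place of 4-fluorophenyl on an aromatic carbon.

The expectation for this move rests on (the limit of > 15600 nM in this assay, at which 2 of the 2 values shown sit), and compound 3 will probably report a limit too. No step beyond the usual scatter is expected, and the estimate amounts to a step that the limit leaves unreadable from compound 2 to compound 3. For compound 3 the estimated value is 20000 nM, within an expected range of 10000 nM to 40000 nM.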

Compound 3, half-maximal cytotoxic concentration: > 3900 nM
Compound 3 was reported as a limit (the forecaster's own chance of this, stated with the estimate: 85%); the middle value lies beyond the limit too.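

In this assay, among these compounds, compound 1, compound 2 and compound 3 all report limits and not numbers, so no step between them can be read. The compounds shown leave open whether adding the fluorine, or moving it from 4-fluorophenyl to 2-fluorophenyl, changes the half-maximal cytotoxic concentration at all.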